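Fluoro to chloro on the triazole aryl group

A few compounds are considered here, and "the series" means these few. Any claim that something is new, unique, unknown or untested is made for them only; others in the source may bear on it.

Compound 1 `C=C1C[C@]23C[C@@]1(O)CC[C@@H]2c1cccc(C)c1[C@@H]3Cn1cc(-c2ccc(Cl)cc2)nn1` gives in a functional assay on HL-60 cells (Homo sapiens) for cytotoxicity, read by MTT assay, with a stated time of 4 days; a higher number here means a weaker inhibitor, a lower number a stronger inhibitor > 20000 nM, which is a limit of the assay rather than a number.
Compound 2 `C=C1C[C@]23C[C@@]1(O)CC[C@H]2c1ccc(OS(=O)(=O)c2ccc(C)cc2)c(C)c1[C@@H]3Cn1cc(-c2ccccn2)nn1` gives in this assay > 20000 nM, again a limit of the assay.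
Compound 3 `C=C1C(=O)[C@]23C[C@@]1(O)CC[C@H]2c1ccc(OS(=O)(=O)c2ccc(C)cc2)c(C)c1[C@@H]3Cn1cc(-c2ccc(F)cc2)nn1` gives in this assay 1290 nM.

Compound 3 thus holds the only number shown in this set; the other two values sit at the limit of > 20000 nM in this assay, at which 2 of the 3 values shown sit.

Compound 4 `C=C1C(=O)[C@]23C[C@@]1(O)CC[C@H]2c1ccc(OS(=O)(=O)c2ccc(C)cc2)c(C)c1[C@@H]3Cn1cc(-c2ccc(Cl)cc2)nn1` differs from compound 3 in one place: chloro in place of fluoro on an aromatic carbon. Among the measured compounds shown here, no pair of measured compounds shows this change, so the step is expected to stay within the usual scatter, in no set direction: from compound 3 to compound 4 the expected step is a 1.1-fold lower number from compound 3 to compound 4 (0.03 log units; within the scatter).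

Compound 4 is estimated at 1200 nM, with a range from 500 nM to 3000 nM.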

Compound 4, half-maximal inhibitory concentration: 1260 nM
For compound 4 the middle estimate is 1.1-fold (0.02 log units) below the measured one; the measured number falls inside the stated range.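

Chloro in place of fluoro at this position, the aromatic carbon para to a large group, gives a 1.0-fold lower number from compound 3 to compound 4 (0.01 log units; within the scatter), so this assay does not separate 4-fluorophenyl from 4-chlorophenyl on this core. Among the compounds shown here, the earlier compounds held no pair differing at this position, and this step is the first reading of it. Compound 3 and compound 4 now carry the only numbers in the set, and the other values are limits of the assay: the limit of > 20000 nM in this assay, at which 2 of the 4 values shown sit.

Two halogens say little about the position as a whole. On these data alone, what an amine or a carboxylic acid in place of the halogen would do to the number stays open.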